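The source may report more compounds than this note shows. Statements on the series, on what has been measured and on what is new or still open speak of the compounds shown alone.

Measured compounds:
compound 1, `CNC(=O)[C@H]1C[C@H]2CNC[C@H]2C1` — "not determined" (no result reported)
compound 2, `O=C(C1CC1)[C@H]1C[C@@H]2CNC[C@@H](C2)C1` — 1300 nM
compound 3, `COC(=O)C1CC2CNCC(C2)C1` — "not determined" (no result reported)

Of these three, only compound 2 carries a number. In an assay on CHO cells for agonist activity at Neuronal acetylcholine receptor; alpha3/beta4 (Homo sapiens), read by FLIPR and calcium flux (a higher number here means that more compound is needed for the effect, a lower number that less compound is needed), compound 2 gives 1300 nM. For compound 1 the result in this assay is "not determined" (no result reported), and for compound 3 it is likewise "not determined" (no result reported), so compound 2 stands alone among the numbers shown and no comparison to another measured compound is possible.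

Compound 4, `CCCNC(=O)[C@H]1C[C@@H]2CNC[C@@H](C2)C1`, is the next compound to be tested in this assay. It differs from compound 2 in a single place: propylamino in place of cyclopropyl on a carbonyl carbon. Among the compounds with values here, no pair of measured compounds shows what such an exchange does on this core, so the size of the step can only be guessed. With a propylamino group entering in place of the cyclopropyl on the carbonyl carbon, the expectation is a change of modest size, with a drift toward a higher value being somewhat more likely than a lower one, though a step within the scatter would not surprise. The estimated step in this assay is a 1.5-fold higher number from compound 2 to compound 4 (0.19 log units; within the scatter). Compound 4 is therefore expected to give about 2000 nM, with a likely range from 500 nM to 8000 nM.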

Compound 4, half-maximal effective concentration: 15000 nM
Compound 4: the middle estimate sits 7.5-fold (0.88 log units) below what was measured; measured number outside the range, above it.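

On this core, the group on the carbonyl carbon clearly matters in this assay: propylamino in place of cyclopropyl gives a 12-fold higher number from compound 2 to compound 4 (1.06 log units; beyond the scatter), so more compound is needed for the effect. The exchange removes the three-membered carbon ring and adds a nitrogen with its hydrogen-bond donor in a single step, so this pair cannot separate the contribution of each change. No available evidence explains the size of this step.

Cyclopropylamino would keep the three-membered ring while adding the nitrogen, and butanoyl would keep an open chain without it, so these two groups could tell the two changes apart. As far as these compounds go, it also remains open whether a shorter chain such as ethylamino, or dimethylamino with no amide hydrogen, would lie closer to compound 2 or to compound 4.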